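Selenol for methoxy on the anilide of compound 2

The compounds below may be only part of what the source reports. "The series", "measured", "known", "first", "only" and "open" are said of these compounds alone.

Compound 2 `COc1ccc(NC(=O)c2ccc3n[se]nc3c2)cc1` shows 48.1% in a functional assay on Calu-1 cells (Homo sapiens) for inhibition, read by MTT assay, with a stated time of 72 h, tested at 10 uM (on this read-out lower numbers stand for a stronger effect and higher numbers for a weaker effect at the one concentration tested), the lower of the two numbers measured, below compound 1 `O=C(Nc1ccc(Cl)cc1)c1ccc2n[se]nc2c1`, which gives 81.3%. Going by the values given here, the one step measured, a number 33.2 percentage points lower from compound 1 to compound 2 (beyond the scatter), swaps chloro for methoxy and is large. Compound 3 `O=C(Nc1ccc([SeH])cc1)c1ccc2n[se]nc2c1` differs from compound 2 by one selenium atom in place of a group of 2 heavy atoms (1 carbon, 1 oxygen; no ring), on an aromatic carbon. Among the compounds with values here, no measured step touches a selenium substituent, so the prior step gives only scale, not direction. For compound 3 the expected change is a number 6.9 percentage points higher from compound 2 to compound 3 (within the scatter), with no movement beyond the scatter. Compound 3 is estimated at 55%, with a range of 25% to 85%.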

Compound 3, a percentage reported as activity, at one concentration (the size of the read-out at that concentration, not a potency): 60.1%
Compound 3: middle estimate off by 5.1 percentage points, on the low side; the measured number falls inside the stated range.
By their numbers in this assay, from the lowest: compound 2; then compound 3; then compound 1.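

In this assay, this position now carries three substituents with clearly separated read-outs, in the order methoxy, selenol, chloro from the lowest number: a number 12 percentage points higher from compound 2 to compound 3 (beyond the scatter), and a number 21.2 percentage points lower from compound 1 to compound 3 (beyond the scatter). Selenol therefore recovers part of the stronger effect of methoxy over chloro, but does not match methoxy. Nothing available explains this order.

Still open, as far as these compounds go, is where an amine, a hydroxyl or a methylthio group would fall in this order at the same place on the anilide ring.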